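A few compounds are considered here, and "the series" means these few. Any claim that something is new, unique, unknown or untested is made for them only; others in the source may bear on it.

Measured compounds:
Compound 1, `Oc1cccc(-c2cc(-c3ccc(Cl)cc3)nc(-c3ccccn3)c2)c1`: 13900 nM
Compound 2, `Oc1cccc(-c2cc(-c3ccc(Cl)cc3)nc(-c3ccco3)c2)c1`: 10500 nM
Compound 3, `Oc1ccc(-c2cc(-c3ccc(Cl)cc3)nc(-c3ccccn3)c2)cc1`: 25900 nM

All three numbers come from a functional assay on T47D cells (Homo sapiens) for cytotoxicity, read by CCK-8 assay and cell counting, with a stated time of 2 days; a higher number here means a weaker inhibitor, a lower number a stronger inhibitor. Compound 1 and compound 2 differ in one place: furan-2-yl in place of pyridin-2-yl on an aromatic carbon. That change gave a 1.3-fold lower number from compound 1 to compound 2 (0.12 log units; within the scatter). Compound 1 and compound 3 are built from the same atoms, joined differently: 4-hydroxyphenyl in place of 3-hydroxyphenyl on an aromatic carbon. Here the step was a 1.9-fold higher number from compound 1 to compound 3 (0.27 log units; within the scatter). Among the measured compounds shown here, compound 3 and compound 2 have no single-point step between them; their two values show a gap beyond the scatter, while compound 3 and compound 1 lie within it.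

Compound 4, `Oc1ccc(-c2cc(-c3ccc(Cl)cc3)nc(-c3ccco3)c2)cc1`, has not yet been measured. It differs from compound 3 in this way: furan-2-yl in place of pyridin-2-yl on an aromatic carbon. This is the same kind of change as that from compound 1 to compound 2, though the surroundings differ: the place is meta to a 4-hydroxyphenyl group rather than meta to a 3-hydroxyphenyl group. Compound 4 is expected to take a step of a 1.3-fold lower number from compound 3 to compound 4 (0.11 log units; within the scatter) in this assay, set beside the earlier step, because the earlier instance of the change gave a 1.3-fold lower number from compound 1 to compound 2 (0.12 log units; within the scatter). Compound 4 is therefore estimated at 20000 nM, most likely between 10000 nM and 40000 nM.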

Compound 4, half-maximal inhibitory concentration: 6260 nM
Compound 4: middle estimate off by 3.2-fold (0.50 log units), on the high side; the measured number lies below the stated range.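

In this assay, furan-2-yl in place of pyridin-2-yl gave a 4.1-fold lower number from compound 3 to compound 4 (0.62 log units; beyond the scatter), and this step did not match the one seen earlier for the same change on the core carrying 3-hydroxyphenyl: the same change on two cores in this assay, a 1.3-fold lower number (0.12 log units; within the scatter) from compound 1 to compound 2 and a 4.1-fold lower number (0.62 log units; beyond the scatter) from compound 3 to compound 4, 3.1-fold (0.49 log units) apart, beyond the scatter of two such steps. In the same way, 4-hydroxyphenyl in place of 3-hydroxyphenyl gave a 1.7-fold lower number from compound 2 to compound 4 (0.22 log units; within the scatter), which also failed to match its earlier instance: the same change on two cores in this assay, a 1.9-fold higher number (0.27 log units; within the scatter) from compound 1 to compound 3 and a 1.7-fold lower number (0.22 log units; within the scatter) from compound 2 to compound 4, 3.1-fold (0.49 log units) apart, beyond the scatter of two such steps. Among the compounds shown here, neither change can therefore be carried from one core to the other as a fixed amount in these four compounds, although this rests on only one pair of steps for each change and does not show what lies behind the difference.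

The compounds shown all keep the 4-chlorophenyl group and carry only pyridin-2-yl or furan-2-yl next to the ring nitrogen, so it remains open whether thiophen-2-yl or an amine at that place would show the same dependence on the hydroxyphenyl group. From the compounds shown here alone, it is also open whether a methoxy group in place of the hydroxyl would behave in the same way.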